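Methoxy added beside a hydroxy group in a thiosemicarbazone series

The source may report more compounds than this note shows. Statements on the series, on what has been measured and on what is new or still open speak of the compounds shown alone.

Compound 1 `CC1=CC[C@H](C(C)(C)NC(=S)N/N=C/c2ccccc2)CC1` gives 8800 nM in a functional assay on HT-29 cells (Homo sapiens) for inhibition, read by sulforhodamine B assay, with a stated time of 48 h; a higher number here means a weaker inhibitor of growth, a lower number a stronger inhibitor of growth. Compound 2 `COc1ccc(/C=N/NC(=S)NC(C)(C)[C@H]2CC=C(C)CC2)cc1` carries methoxy in place of hydrogen on an aromatic carbon and gives 8400 nM, a change of a 1.0-fold lower number from compound 1 to compound 2 (0.02 log units; within the scatter). Compound 3 `CC1=CC[C@H](C(C)(C)NC(=S)N/N=C/c2ccc(O)cc2)CC1` differs from compound 1 by hydroxy in place of hydrogen on an aromatic carbon. In this assay compound 3 reaches only the assay limit of > 100000 nM, so the steps of an at least 11-fold higher number from compound 1 to compound 3 (1.05 log units; beyond the scatter) and an at least 11-fold higher number from compound 2 to compound 3 (1.07 log units; beyond the scatter) are themselves only limits. Compound 4 `COc1cc(/C=N/NC(=S)NC(C)(C)[C@H]2CC=C(C)CC2)ccc1O` has not been measured; it differs from compound 3 by methoxy in place of hydrogen on an aromatic carbon. This is the same kind of change as from compound 1 to compound 2, though there the methoxy entered para to a large group, whereas here it enters ortho to a hydroxy group and meta to a large group. Compound 4 is expected to stay near the same limit as compound 3, because a 1.0-fold lower number from compound 1 to compound 2 (0.02 log units; within the scatter) shows that this kind of change barely moved the number, giving an expected step that the limit leaves unreadable from compound 3 to compound 4. Compound 4 is thus estimated at 120000 nM, within 30000 nM to 400000 nM.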

Compound 4, concentration for 50% growth inhibition: < 40 nM
Compound 4: no number, only a limit (the forecaster's own chance of this, stated with the estimate: 60%); middle value at least 3000-fold (3.47 log units) away from the limit.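

In this assay, methoxy in place of hydrogen on an aromatic carbon, here ortho to a hydroxy group, gives an at least 2500-fold lower number from compound 3 to compound 4 (3.39 log units; beyond the scatter). Both ends of this step are limits of the assay rather than numbers, so its exact size cannot be read. The result on one core therefore did not carry over to the other, and these compounds do not show why: the same change on two cores in this assay, a 1.0-fold lower number (0.02 log units; within the scatter) from compound 1 to compound 2 and an at least 2500-fold lower number (3.39 log units; beyond the scatter) from compound 3 to compound 4, at least 2300-fold (3.37 log units) apart, beyond the scatter of two such steps

Still open, going by these compounds, is whether another group in the same place, such as ethoxy or an amine, would act as methoxy does here. Also open, on these data alone, is whether methoxy in that place would give the same result without the hydroxy group.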